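The compounds below may be only part of what the source reports. "The series", "measured", "known", "first", "only" and "open" are said of these compounds alone.

The account starts from compound 1 (`O=c1cc(-c2ccc([N+](=O)[O-])cc2)oc2cc(O)ccc12`), which in a functional assay on Malme-3M cells (Homo sapiens) for cytotoxicity, read by MTT assay, with a stated time of 6 days (on this read-out higher numbers stand for an effect only at larger amounts of compound and lower numbers for an effect already at smaller amounts), gives > 25 ug/mL as a limit of the assay and not a number. Compound 3 (`COc1cc(-c2cc(=O)c3ccc(OC)c(OC)c3o2)cc(OC)c1OC`) gives > 25 ug/mL as a limit too. Compound 1 therefore stands at the limit of > 25 ug/mL in this assay, at which 2 of the 3 values shown sit, and no number fixes it more closely. Compound 2 (`O=c1cc(-c2ccc([N+](=O)[O-])cc2)oc2c(O)c(O)ccc12`) carries hydroxy in place of hydrogen on an aromatic carbon of the shared core and gives 3.61 ug/mL as a measured number. Compound 4 (`CC(C)(C)[Si](C)(C)Oc1ccc(-c2cc(=O)c3ccc(O)cc3o2)cc1`) keeps the core of compound 1 without that added hydroxy and changes another place, where nitro leaves: a group of 8 heavy atoms (6 carbon, 1 oxygen, 1 silicon; no ring) in place of a group of 3 heavy atoms (1 nitrogen, 2 oxygen; no ring), on an aromatic carbon. For the measured compounds named here, no measured step touches that place. The only one available, an at least 6.9-fold lower number from compound 1 to compound 2 (0.84 log units; beyond the scatter), concerns the added hydroxy, so no step beyond the scatter is expected in this assay here. The expected change is an at least 1.2-fold lower number from compound 1 to compound 4 (0.09 log units; that floor lies within the scatter) and a reading at the limit remains likely. For compound 4 the estimated value is 20 ug/mL within an expected range of 7 ug/mL to 50 ug/mL.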

Compound 4, concentration for half-maximal effect: > 10 ug/mL
Compound 4: a limit, no number; the forecaster's own chance of this, stated with the estimate: 55%; the middle value is on the limit's open side.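

In this assay compound 4 gives > 10 ug/mL, a limit of the assay and not a number. Compound 1 also stands at a limit, and the step from compound 1 to compound 4 cannot be read. The compounds shown leave open whether the group of 8 heavy atoms in place of nitro changes the effect at all.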